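From 4-fluorophenyl to 4-(trifluoromethyl)phenyl on the sulfonamide nitrogen

The source may report more compounds than this note shows. Statements on the series, on what has been measured and on what is new or still open speak of the compounds shown alone.

In a functional assay on DU-145 cells (Homo sapiens) for inhibition, read by CCK-8 assay, with a stated time of 72 h (a higher number here means a weaker inhibitor, a lower number a stronger inhibitor), compound 1 (`Cc1ccc(NS(=O)(=O)c2cccc(CCCCCCNC(=O)/C=C/c3cccnc3)c2)cc1`) gives 34.4 nM and compound 2 (`Cc1cccc(NS(=O)(=O)c2cccc(CCCCCCNC(=O)/C=C/c3cccnc3)c2)c1`) gives 41.7 nM with a 1.2-fold higher number from compound 1 to compound 2 (0.08 log units; within the scatter) between them. Compound 3 (`O=C(/C=C/c1cccnc1)NCCCCCCc1cccc(S(=O)(=O)Nc2ccc(F)cc2)c1`) gives 10.6 nM as the lowest number of the three, reached by a 3.2-fold lower number from compound 1 to compound 3 (0.51 log units; beyond the scatter) and by a 3.9-fold lower number from compound 2 to compound 3 (0.59 log units; beyond the scatter) in the other comparison.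

Compound 4 (`O=C(/C=C/c1cccnc1)NCCCCCCc1cccc(S(=O)(=O)Nc2ccc(C(F)(F)F)cc2)c1`) differs from compound 3 by trifluoromethyl in place of fluoro on an aromatic carbon, para to a large group. Among the compounds with values here, no measured step covers this exchange directly, and the series holds no trifluoromethyl example. Within the data shown here, the closest evidence is the exchange of methyl for fluoro in a 3.2-fold lower number from compound 1 to compound 3 (0.51 log units; beyond the scatter) as the only measured change at this place with a size beyond the scatter. Read in reverse, it suggests that losing the fluoro of compound 3 may cost a modest step towards a higher number. The step expected is a 2.3-fold higher number from compound 3 to compound 4 (0.35 log units; beyond the scatter) in this assay on that basis. The estimated value for compound 4 is 24 nM with an expected range from 8 nM to 70 nM for now.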

Compound 4, half-maximal inhibitory concentration: 1410 nM
Estimate against measurement, compound 4: 59-fold (1.77 log units) below; the measured number lies above the stated range.
By their numbers in this assay, from the lowest: compound 3; then compounds 1 and 2 (each within the scatter of the next); then compound 4.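

In this assay this place on the aromatic ring, para to a large group, had so far shown only modest steps, but trifluoromethyl in place of fluoro gives a large one (a 130-fold higher number from compound 3 to compound 4 (2.12 log units; beyond the scatter)). The loss does not depend on fluoro as the reference: trifluoromethyl in place of methyl also gives a large step (a 41-fold higher number from compound 1 to compound 4 (1.61 log units; beyond the scatter)), as does the exchange of the 3-methylphenyl group for 4-(trifluoromethyl)phenyl (a 34-fold higher number from compound 2 to compound 4 (1.53 log units; beyond the scatter)), so compound 4 stands apart from the other three compounds. Nothing measured here accounts for this drop.

Open, on these data alone, is whether chloro, methoxy or an ethyl group at the same place stays close to compound 3 or falls towards compound 4. Also open, as far as these compounds go, is whether a 3-(trifluoromethyl)phenyl group on the sulfonamide nitrogen carries the same loss.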